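The compounds below may be only part of what the source reports. "The series", "measured", "known", "first", "only" and "open" are said of these compounds alone.

Within the data shown here, in a functional assay on K562 cells (Homo sapiens) for antiproliferative activity, with a stated time of 72 h (on this read-out lower numbers stand for stronger inhibition and higher numbers for weaker inhibition), three compounds have numbers so far. Compound 1 `OC[C@H]1O[C@@H](n2cnc3c(NCc4ccccc4F)ncnc32)[C@H](O)[C@@H]1O` gives 33200 nM, compound 2 `OC[C@H]1O[C@@H](n2cnc3c(NCc4ccc(F)cc4)ncnc32)[C@H](O)[C@@H]1O` gives 2700 nM and compound 3 `COc1ccccc1CNc1ncnc2c1ncn2[C@@H]1O[C@H](CO)[C@@H](O)[C@H]1O` gives 89000 nM. Compound 3 is the weakest of the three, with both gaps to the others beyond the scatter.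

The next analogue is compound 4 `COc1ccc(CNc2ncnc3c2ncn3[C@@H]2O[C@H](CO)[C@@H](O)[C@H]2O)c(OC)c1`. The change is methoxy in place of hydrogen on an aromatic carbon, meta to a methoxy group and para to a large group, turning 2-methoxyphenyl into 2,4-dimethoxyphenyl.

Among the measured compounds shown here, no measured step adds a group at this place directly, so the evidence is indirect. The closest is the large 12-fold lower number from compound 1 to compound 2 (1.09 log units; beyond the scatter), in which compound 2 carries fluoro at the ring place that methoxy fills in compound 4. Methoxy has not matched fluoro so far, as shown by the modest 2.7-fold higher number from compound 1 to compound 3 (0.43 log units; beyond the scatter) and the large 33-fold higher number from compound 2 to compound 3 (1.52 log units; beyond the scatter). Compound 4 also keeps the methoxy of compound 3, so only part of the drop seen with compound 2 is expected to carry over.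

The step expected in this assay is a 3.6-fold lower number from compound 3 to compound 4 (0.55 log units; beyond the scatter), moderate and towards a lower number. For compound 4 the estimated value is 25000 nM, with an expected range of 6000 nM to 100000 nM.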

Compound 4, half-maximal inhibitory concentration: > 166000 nM
Compound 4: no number, only a limit (the forecaster's own chance of this, stated with the estimate: 20%); middle value at least 6.6-fold (0.82 log units) from the limit.
By their numbers in this assay, from the lowest: compound 2; then compound 1; then compound 3. At a limit, above all of these: compound 4.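

In this assay compound 4 gives only a limit, not a number: the limit of > 166000 nM in this assay, at which 1 of the 4 values shown sits. Methoxy in place of hydrogen, para to a large group, brings no lower number on the 2-methoxyphenyl ring, with the step reading an at least 1.8-fold higher number from compound 3 to compound 4 (0.27 log units; that floor lies within the scatter); that floor lies within the scatter, so a real rise is not shown by the limit alone, and only the absence of a gain is firm. The 2,4-dimethoxyphenyl group also stands well clear of both fluorinated rings, at an at least 61-fold higher number from compound 2 to compound 4 (1.78 log units; beyond the scatter) and an at least 5.0-fold higher number from compound 1 to compound 4 (0.69 log units; beyond the scatter), so filling this ring place does not by itself bring the low number seen with 4-fluorophenyl.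

The compounds shown leave open how far the true value of compound 4 lies beyond its limit, and whether methoxy at this place gives the same result on a ring without the second methoxy group. Going by these compounds, how chloro, methyl, an amine or a carboxylic acid would behave at this same ring place also remains open, and only such groups can show whether fluoro is a special case here.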